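Compound 3: fluoro to hydrogen on the pendant aryl ring

The source may hold more compounds than are shown below. What is called first, only, known or untested is meant among the compounds shown, and "the series" means these compounds.

Compound 1 `COc1ccc(S(=O)(=O)N2CCc3cccc(-c4ccc(N(C)C)cc4)c32)cc1` and compound 2 `COc1ccc(S(=O)(=O)N2CCc3cccc(-c4ccc(F)cc4)c32)cc1` share one core and differ only in the substituent on the outer aryl ring. In a functional assay on HT-29 cells (Homo sapiens) for inhibition, with a stated time of 72 h (a lower number here means a stronger inhibitor, a higher number a weaker inhibitor), compound 1 gives 467 nM, and compound 2 gives 85.5 nM. Among the compounds with values here, the step of a 5.5-fold lower number from compound 1 to compound 2 (0.74 log units; beyond the scatter) is the only measured step in the set so far. Compound 2 therefore stands lowest of the two numbers, with compound 1 its nearest neighbour at a higher value beyond the scatter.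

Compound 3 `COc1ccc(S(=O)(=O)N2CCc3cccc(-c4ccccc4)c32)cc1` is compound 2 with hydrogen in place of fluoro on an aromatic carbon. Within the data shown here, no measured step exchanges fluoro for hydrogen; the one step at hand, a 5.5-fold lower number from compound 1 to compound 2 (0.74 log units; beyond the scatter), concerns dimethylamino against fluoro and bears only indirectly. Among the measured compounds shown here, with no direct precedent, only a small move is expected in this assay, if any beyond the scatter, its direction expected toward a slightly higher number. Compound 3 is estimated at 130 nM, with a range from 50 nM to 350 nM, which means an expected step of a 1.5-fold higher number from compound 2 to compound 3 (0.18 log units; within the scatter).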

Compound 3, half-maximal inhibitory concentration: 96.5 nM
Compound 3: middle estimate off by 1.3-fold (0.13 log units), on the high side; measured number inside the range.
By their numbers in this assay, from the lowest: compounds 2 and 3 (each within the scatter of the next); then compound 1.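

In this assay, the change from 4-fluorophenyl to phenyl gives no readable difference (a 1.1-fold higher number from compound 2 to compound 3 (0.05 log units; within the scatter)), so fluoro on this aromatic carbon, para to a large group, cannot be told apart from hydrogen. The difference from dimethylamino is therefore not tied to fluoro: it is beyond the scatter with hydrogen (a 4.8-fold lower number from compound 1 to compound 3 (0.68 log units; beyond the scatter)) as with fluoro (a 5.5-fold lower number from compound 1 to compound 2 (0.74 log units; beyond the scatter)), and among these three compounds only compound 1 stands apart. Nothing on hand explains this difference.

Still open, on these data alone, is whether the higher number of compound 1 is particular to dimethylamino or is shared by other groups at this position, such as a primary amine or morpholine. A carboxylic acid or a methoxy group at the same place would show how far this position tolerates change beyond fluoro and hydrogen.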